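Varying the aryl group on the shared core

The source may hold more compounds than are shown below. What is called first, only, known or untested is meant among the compounds shown, and "the series" means these compounds.

Within the data shown here, compound 2 `O=C(CSc1nnc(-c2ccncc2)o1)N/N=C/c1ccccc1O` gives the lowest of the two numbers so far in a functional assay on HepG2 cells (Homo sapiens) for cytotoxicity, read by MTT assay, with a stated time of 48 h (a higher number here means a weaker inhibitor, a lower number a stronger inhibitor), at 3510 nM. Its nearest neighbour is compound 1 `COc1cccc(/C=N/NC(=O)CSc2nnc(-c3ccncc3)o2)c1`, which in this assay gives 9170 nM; the step of a 2.6-fold lower number from compound 1 to compound 2 (0.42 log units; beyond the scatter) lies beyond the scatter. Compound 3 `COc1cc(/C=N/NC(=O)CSc2nnc(-c3ccncc3)o2)ccc1O` differs from compound 2 by 4-hydroxy-3-methoxyphenyl in place of 2-hydroxyphenyl on a carbon with a double bond to nitrogen. Among the measured compounds shown here, the only measured step that bears on this change is a 2.6-fold lower number from compound 1 to compound 2 (0.42 log units; beyond the scatter), which also exchanged one aryl group for another at the same place and moved the number modestly. It shows that such an exchange can shift the number beyond the scatter, but compound 1 and compound 2 together give no direction for a 4-hydroxy-3-methoxyphenyl group, which combines the methoxy of compound 1 with the hydroxyl of compound 2. No step beyond the scatter is therefore expected. Compound 3 is estimated at 5000 nM, with a range of 2000 nM to 12000 nM, meaning an expected step of a 1.4-fold higher number from compound 2 to compound 3 (0.15 log units; within the scatter).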

Compound 3, half-maximal inhibitory concentration: 2920 nM
Beside the measured number, compound 3's estimate is 1.7-fold (0.23 log units) above it; low and high end bracket the measured number.
By their numbers in this assay, from the lowest: compounds 3 and 2 (each within the scatter of the next); then compound 1.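

In this assay, 4-hydroxy-3-methoxyphenyl in place of 2-hydroxyphenyl on a carbon with a double bond to nitrogen gives a 1.2-fold lower number from compound 2 to compound 3 (0.08 log units; within the scatter), so this position accepts both aryl groups with no separation in the number. Hydroxy in place of hydrogen on an aromatic carbon gives a 3.1-fold lower number from compound 1 to compound 3 (0.50 log units; beyond the scatter), a step beyond the scatter that leaves the methoxy group in place, so among these three compounds both hydroxy-bearing aryl groups sit lower than 3-methoxyphenyl, with no compound against this. Nothing available accounts for these steps.

As far as these compounds go, whether the placing of the hydroxy group on the ring matters by itself remains open, since compound 2 and compound 3 also differ in the methoxy group. Also open, from the compounds shown here alone, is how an amine or a carboxylic acid in place of the hydroxy group would read at this position.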